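Swapping nitro for methoxy on the triazole-linked phenyl ring

A few compounds are considered here, and "the series" means these few. Any claim that something is new, unique, unknown or untested is made for them only; others in the source may bear on it.

Measured so far:
- compound 1, `COc1ccc(/C=C\C(=O)O)c(OCc2cn(-c3cccc([N+](=O)[O-])c3)nn2)c1CC=C(C)C`: 43200 nM
- compound 2, `COc1ccc(/C=C\C(=O)O)c(OCc2cn(-c3ccccc3C#N)nn2)c1CC=C(C)C`: 14400 nM
- compound 3, `COc1ccc(/C=C\C(=O)O)c(OCc2cn(-c3ccc(NC(=O)c4ccccc4)cc3)nn2)c1CC=C(C)C`: 17200 nM

All three share one core and differ only in the aryl group carried on the triazole nitrogen. In a functional assay on NCI-H322 cells (Homo sapiens) for cytotoxicity, read by MTT assay, with a stated time of 24 h (on this read-out higher numbers stand for weaker inhibition and lower numbers for stronger inhibition), compound 1 gives the highest number of the three, so it is the weakest inhibitor among them; the step of a 3.0-fold lower number from compound 1 to compound 2 (0.48 log units; beyond the scatter) is modest but beyond the scatter, and the value of compound 3 lies below that of compound 1 by a similar margin.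

Compound 4, `COc1cccc(-n2cc(COc3c(/C=C\C(=O)O)ccc(OC)c3CC=C(C)C)nn2)c1`, is not yet measured. It differs from compound 1 in one place: methoxy in place of nitro on an aromatic carbon. For the measured compounds named here, no measured pair changes exactly this group, so the only guide is indirect. Going by the values given here, the one measured step from compound 1, a 3.0-fold lower number from compound 1 to compound 2 (0.48 log units; beyond the scatter), shows that replacing the nitro-bearing ring lowered the number, and compound 3 points the same way. On that basis a modest lowering, not a large one, is expected for compound 4 in this assay, as a 2.0-fold lower number from compound 1 to compound 4 (0.29 log units; within the scatter). Compound 4 is therefore estimated at 22000 nM, within a range from 8000 nM to 60000 nM.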

Compound 4, half-maximal inhibitory concentration: 25200 nM
For compound 4 the middle estimate is 1.1-fold (0.06 log units) below the measured one, within the range that was stated.
By their numbers in this assay, from the lowest: compounds 2, 3, 4 and 1 (each within the scatter of the next, the first and the last beyond it).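

Unlike the step to compound 2, which alters both the group and where it sits, the change to compound 4 keeps the place on the aromatic ring, meta to a large group, and exchanges only nitro for methoxy. In this assay this exchange gives a 1.7-fold lower number from compound 1 to compound 4 (0.23 log units; within the scatter) so, at this place, replacing nitro with methoxy produces no change that can be told from repeat-measurement noise. The comparison with the other aryl group gives a 1.8-fold higher number from compound 2 to compound 4 (0.24 log units; within the scatter) which also stays within the scatter, so compound 4 cannot be grouped firmly with either compound 1 or compound 2, even though those two differ from each other beyond the scatter.

The compounds shown leave open whether an amine, a hydroxyl or a carboxylic acid at this same place would shift the number beyond the scatter, and whether methoxy on another carbon of the ring would behave as it does here. Nothing available explains why these numbers fall where they do.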